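A few compounds are considered here, and "the series" means these few. Any claim that something is new, unique, unknown or untested is made for them only; others in the source may bear on it.

Measured compounds:
compound 1 `COc1ccc(/C=C/c2cc(OC)cc(OC)c2/C=C/C(=O)NC2CC2)cc1`, in a functional assay on MCF7 cells (Homo sapiens) for inhibition, read by MTT assay, with a stated time of 48 h (a higher number here means a weaker inhibitor, a lower number a stronger inhibitor), 3940 nM
compound 2 `CCCCCCCCNC(=O)/C=C/c1c(/C=C/c2ccc(OC)cc2)cc(OC)cc1OC`, 4280 nM
compound 3 `COc1ccc(/C=C/c2cc(OC)cc(OC)c2/C=C/C(=O)N2CCC(Cl)CC2)cc1`, 4950 nM

Among these three numbers compound 2 stands second highest, yet the steps of a 1.1-fold higher number from compound 1 to compound 2 (0.04 log units; within the scatter) and a 1.2-fold higher number from compound 2 to compound 3 (0.06 log units; within the scatter) both lie within the usual scatter, so the three compounds behave alike.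

Compound 4 `COc1ccc(/C=C/c2cc(OC)cc(OC)c2/C=C/C(=O)Nc2cc(OC)c(OC)c(OC)c2)cc1` has not yet been measured. It differs from compound 2 in one place: 3,4,5-trimethoxyphenyl in place of octyl on an amide-type nitrogen. The measured steps that bear on this all change the group on the same amide-type nitrogen: a 1.1-fold higher number from compound 1 to compound 2 (0.04 log units; within the scatter), a 1.3-fold higher number from compound 1 to compound 3 (0.10 log units; within the scatter) and a 1.2-fold higher number from compound 2 to compound 3 (0.06 log units; within the scatter), each within the scatter. None of them brought in an aromatic ring, so this change is less well covered. Still, on this evidence no step beyond the scatter is expected in this assay for compound 4, with a 1.0-fold higher number from compound 2 to compound 4 (0.00 log units; within the scatter). Compound 4 is therefore estimated at 4300 nM, with a range from 1500 nM to 13000 nM.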

Compound 4, half-maximal inhibitory concentration: 7010 nM
Compound 4: the middle estimate sits 1.6-fold (0.21 log units) below what was measured, and the stated range covers the measured number.
By their numbers in this assay, from the lowest: compounds 1, 2, 3 and 4 (each within the scatter of the next).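

Among these compounds, for the first time an aromatic ring sits on the amide-type nitrogen, and in this assay 3,4,5-trimethoxyphenyl gives a 1.6-fold higher number from compound 2 to compound 4 (0.21 log units; within the scatter) and a 1.8-fold higher number from compound 1 to compound 4 (0.25 log units; within the scatter) and so stays within the scatter of both octyl and cyclopropyl. Across the compounds shown, this position accepts a chain, a small ring and a substituted aromatic ring with no step beyond the scatter. Nothing measured here offers an explanation for these small steps. The compounds shown leave open whether a plain phenyl, or a chain ending in an amine or a carboxylic acid, would do the same on this nitrogen.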